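Side-group changes on the shared core: cytotoxicity notes

A few compounds are considered here, and "the series" means these few. Any claim that something is new, unique, unknown or untested is made for them only; others in the source may bear on it.

- Compound 1 `CNCc1ccc2c(c1)nc(Cn1c(=O)n(C(C)C)c3ccccc31)n2CCC(C)C`: 1480 nM
- Compound 2 `CCc1ccc2c(c1)nc(Cn1c(=O)n(C(C)C)c3ccccc31)n2CCC(C)C`: 18500 nM
- Compound 3 `CC(C)CCn1c(Cn2c(=O)n(C(C)C)c3ccccc32)nc2cc(-c3ncon3)ccc21`: 223000 nM

In an ADME assay on HEp-2 cells (Homo sapiens) for cytotoxicity (on this read-out higher numbers stand for lower toxicity in this test and lower numbers for higher toxicity in this test), compound 3 has the highest number of the three. Compound 4 `CC(C)CCn1c(Cn2c(=O)n(C(C)C)c3ccccc32)nc2cc(C(=O)N(C)C)ccc21` has not yet been measured. It differs from compound 3 by dimethylcarbamoyl in place of 1,2,4-oxadiazol-3-yl on an aromatic carbon. Within the data shown here, two measured steps bear on this, a 12-fold higher number from compound 2 to compound 3 (1.08 log units; beyond the scatter) and a 150-fold higher number from compound 1 to compound 3 (2.18 log units; beyond the scatter). Both are large, and both end on the group that now leaves. Among the measured compounds shown here, no measured step involves dimethylcarbamoyl, so the size remains uncertain. A moderate move to a lower number is expected in this assay, giving up part of a 12-fold higher number from compound 2 to compound 3 (1.08 log units; beyond the scatter). The expected change is a 3.2-fold lower number from compound 3 to compound 4 (0.50 log units; beyond the scatter). For compound 4 the estimate is 70000 nM, with an expected range of 18000 nM to 250000 nM.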

Compound 4, half-maximal cytotoxic concentration: 25600 nM
Compound 4: the middle estimate sits 2.7-fold (0.44 log units) above what was measured; measured number inside the range.
By their numbers in this assay, from the lowest: compound 1; then compounds 2 and 4 (each within the scatter of the next); then compound 3.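

In this assay, exchanging 1,2,4-oxadiazol-3-yl for dimethylcarbamoyl, a group with the same number of heavy atoms, still shifts the result on this aromatic carbon (an 8.7-fold lower number from compound 3 to compound 4 (0.94 log units; beyond the scatter)). Dimethylcarbamoyl and ethyl cannot be told apart here (a 1.4-fold higher number from compound 2 to compound 4 (0.14 log units; within the scatter)), yet dimethylcarbamoyl stays clearly separated from (methylamino)methyl (a 17-fold higher number from compound 1 to compound 4 (1.24 log units; beyond the scatter)), so among these groups only 1,2,4-oxadiazol-3-yl reaches the top of the series. No supporting measurement accounts for these differences.

Open, from the compounds shown here alone, is where a carboxylic acid, a secondary amide or a longer amine chain on this aromatic carbon would fall. The shown compounds also leave open whether another five-membered aromatic ring would match 1,2,4-oxadiazol-3-yl.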